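The compounds below may be only part of what the source reports. "The series", "measured", "known", "first", "only" and "open" are said of these compounds alone.

For the measured compounds named here, in a functional assay on cells (Panel colon (Carcinoma cell lines), Homo sapiens) for inhibition (on this read-out higher numbers stand for weaker inhibition of growth and lower numbers for stronger inhibition of growth), compound 1 (`Cc1ccc2c(O)cc(-c3cccc(Cl)c3)nc2n1`) gives 3090 nM, the lowest of the three numbers measured so far. Compound 2 (`Cc1cc(C)c2c(O)cc(-c3cccc(Cl)c3)nc2n1`) gives 28800 nM, and compound 3 (`Cc1cnc2[nH]c(-c3cccc(Cl)c3)cc(=O)c2c1`), which also carries a single methyl, gives 9550 nM. Compound 4 (`Oc1cc(-c2cccc(Cl)c2)nc2ncccc12`) has not yet been measured. It has hydrogen in place of methyl on an aromatic carbon, next to the ring nitrogen: hydrogen in place of methyl on an aromatic carbon.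

Going by the values given here, only one measured step involves a methyl on this core: a 9.3-fold higher number from compound 1 to compound 2 (0.97 log units; beyond the scatter). That step adds a second methyl on another aromatic carbon rather than removing the existing one, so it is only a loose guide. Read in reverse, it hints that losing a methyl could lower the number. Against this, compound 1 at 3090 nM already lies under both of its relatives, so a modest rise looks slightly more likely than a further fall. The expected change is a 1.9-fold higher number from compound 1 to compound 4 (0.29 log units; within the scatter), though its direction remains uncertain. For compound 4 the estimate is 6000 nM, with an expected range from 1800 nM to 20000 nM.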

Compound 4, concentration for total growth inhibition: 16200 nM
Beside the measured number, compound 4's estimate is 2.7-fold (0.43 log units) below it, and the stated range covers the measured number.
By their numbers in this assay, from the lowest: compound 1; then compounds 3, 4 and 2 (each within the scatter of the next, the first and the last beyond it).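

On the aromatic carbon next to the ring nitrogen, hydrogen in place of methyl weakens growth inhibition in this assay (a 5.2-fold higher number from compound 1 to compound 4 (0.72 log units; beyond the scatter)), so this methyl goes with the stronger result. The earlier step, which added a second methyl on another aromatic carbon (a 9.3-fold higher number from compound 1 to compound 2 (0.97 log units; beyond the scatter)), therefore cannot mean that fewer methyl groups give a lower number: removing this methyl and adding that one both raise the number from the same starting point. No measurement shown explains why either change has this result.

With only hydrogen and methyl seen on this carbon, the compounds leave open whether a longer chain such as ethyl, a methoxy group or an amine there would lower the number further or raise it. They also leave open whether moving the single methyl elsewhere on the shared core would keep the number of the methyl compound.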